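Dichloroacetamide series: step from compound 3 to compound 4

The compounds below may be only part of what the source reports. "The series", "measured", "known", "first", "only" and "open" are said of these compounds alone.

Measured compounds:
compound 1 `O=C(Nc1ccccc1)C(Cl)Cl`, in a functional assay on Bel-7402 cells (Homo sapiens) for antiproliferative activity, read by MTT assay, with a stated time of 72 h (on this read-out higher numbers stand for weaker inhibition and lower numbers for stronger inhibition), compound 1 gives "not determined" (no result reported)
compound 2 `O=C(Nc1ccc(Cl)cc1)C(Cl)Cl`, in this assay compound 2 gives 49600 nM
compound 3 `O=C(Nc1ccc(Br)cc1)C(Cl)Cl`, in this assay compound 3 gives 9770 nM

Compound 3 holds the lowest of the two numbers available in this assay; its nearest neighbour is compound 2, and the one-point step between them, a 5.1-fold lower number from compound 2 to compound 3 (0.71 log units; beyond the scatter), lies beyond the scatter. Compound 1 carries no number in this assay, so it gives no bearing.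

Compound 4 `O=C(Nc1ccc(SC(F)(F)F)cc1)C(Cl)Cl` is not yet measured. It differs from compound 3 in one place: (trifluoromethyl)sulfanyl in place of bromo on an aromatic carbon.

Within the data shown here, only one measured step bears on this change, the exchange of one halogen for another at the same aromatic carbon in a 5.1-fold lower number from compound 2 to compound 3 (0.71 log units; beyond the scatter), which was modest in size and moved the number down. The step to compound 4 replaces the bromo with a group of five heavy atoms, a change of a different kind, so the measured step is only a loose guide; a modest lowering or no change beyond the scatter is the expectation.

Compound 4 is expected to give 5000 nM in this assay, within a range of 1200 nM to 25000 nM, which means an estimated step of a 2.0-fold lower number from compound 3 to compound 4 (0.29 log units; within the scatter).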

Compound 4, half-maximal inhibitory concentration: 3610 nM
Estimate against measurement, compound 4: 1.4-fold (0.14 log units) above; the measured number falls inside the stated range.
By their numbers in this assay, from the lowest: compound 4; then compound 3; then compound 2.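

In this assay the aromatic carbon para to a group of 6 heavy atoms is not limited to halogens: (trifluoromethyl)sulfanyl, with 5 heavy atoms, replaces bromo and gives a 2.7-fold lower number from compound 3 to compound 4 (0.43 log units; beyond the scatter), so the downward movement seen earlier within the halogen pair also continues with a larger group that is not a halogen. Among these compounds, measured against the chloro compound, the same change gives a 14-fold lower number from compound 2 to compound 4 (1.14 log units; beyond the scatter), the only large step so far, and it exceeds a 5.1-fold lower number from compound 2 to compound 3 (0.71 log units; beyond the scatter); among the three compounds with numbers the order is therefore chloro, then bromo, then (trifluoromethyl)sulfanyl, each step beyond the scatter. No measurement on these compounds accounts for this order.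

Compound 1 has no number, so how any of the three groups compares with a plain hydrogen at this carbon remains unread. On these data alone, whether an amine, a carboxylic acid or a longer alkyl chain at this carbon would extend the same downward movement, and whether it would survive a change to the dichloroacetyl part of the shared core, remains open.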